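A few compounds are considered here, and "the series" means these few. Any claim that something is new, unique, unknown or untested is made for them only; others in the source may bear on it.

Measured compounds:
compound 1 `O=c1c2cnn(-c3ccc(F)cc3)c2ncn1CC1(O)CCN(Cc2ccc(F)cc2)CC1` — "not determined" (no result reported) in an assay on Sf21 cells for inhibition of ubiquitin carboxyl-terminal hydrolase 7 (Homo sapiens), read by spectrophotometry, with stated times of 30 min and 2 h; a higher number here means a weaker inhibitor, a lower number a stronger inhibitor
compound 2 `O=c1c2cnn(-c3ccc(F)cc3)c2ncn1CC1(O)CCN(Cc2ccccc2Cl)CC1` — 3400 nM

Compound 2 holds the only number shown in this assay; compound 1 stands without one, so no step between measured compounds can be read. Compound 3 `O=c1c2cnn(-c3ccc(F)cc3)c2ncn1CC1(O)CCN(Cc2ccc(Cl)cc2)CC1` differs from compound 2 in one place: 4-chlorophenyl in place of 2-chlorophenyl on a saturated chain carbon bound to an amine nitrogen in a ring. With no comparison to lean on, the step from compound 2 to compound 3 is expected to stay within the scatter, in no particular direction, estimated as a 1.1-fold lower number from compound 2 to compound 3 (0.05 log units; within the scatter). Compound 3 is therefore estimated at 3000 nM in this assay, within a range of 1000 nM to 10000 nM.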

Compound 3, half-maximal inhibitory concentration: 8000 nM
The estimate for compound 3 lay 2.7-fold (0.43 log units) below the measured number, within the range that was stated.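

In this assay, the first readable step is a 2.4-fold higher number from compound 2 to compound 3 (0.37 log units; beyond the scatter). It shows that at this position, on a saturated chain carbon bound to an amine nitrogen in a ring, where the chlorine sits on the phenyl matters, as 4-chlorophenyl gives the weaker inhibitor of the two. No evidence at hand accounts for this difference.

Compound 1 is recorded as "not determined" (no result reported), so steps involving it cannot be read. As far as these compounds go, how an unsubstituted phenyl or a 3-chlorophenyl in this place would compare with compound 2 and compound 3 remains open.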